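The compounds below may be only part of what the source reports. "The series", "measured", "known", "first", "only" and "open" are said of these compounds alone.

Notes on the series in a functional assay on RAW264.7 cells (Mus musculus) for inhibition, read by Griess assay, with stated times of 1 h and 24 h; a lower number here means a stronger inhibitor, a higher number a weaker inhibitor. Compound 1 `COc1cc(OC)c2c(c1)C(C(O)c1ccc(O)cc1)OC2=O` gives > 10000 nM, a limit of the assay and not a number. Compound 2 `CCOc1ccc(C(O)C2OC(=O)c3c(OC)cc(OC)cc32)cc1` gives > 10000 nM, also a limit. For the measured compounds named here, compound 3 `COCCCCOc1ccc(C(O)C2OC(=O)c3c(OC)cc(OC)cc32)cc1` gives 8210 nM, the only true number among the three. Its standing relative to the other two can be read only against those limits.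

The next change leads to compound 4 `COc1cc(OC)c2c(c1)C(C(O)c1ccc(OCc3ccc(C)cc3)cc1)OC2=O`: 4-methylphenyl in place of 3-methoxypropyl on a saturated chain carbon bound to an oxygen on an aromatic ring. The same difference reads as 4-methoxybutyl to 4-methylbenzyl.

The measured steps that bear on it all vary the group on the oxygen on an aromatic ring: a step that the two limits leave unreadable from compound 1 to compound 2, an at least 1.2-fold lower number from compound 1 to compound 3 (0.08 log units; that floor lies within the scatter) and an at least 1.2-fold lower number from compound 2 to compound 3 (0.08 log units; that floor lies within the scatter). None of them brings in a ring, and none gives a readable size beyond the scatter, so they offer no firm guide to direction. With compound 3 at 8210 nM as the only anchor, no shift beyond the scatter is expected in this assay. A reading at the limit remains possible. The expected change is a 1.2-fold lower number from compound 3 to compound 4 (0.07 log units; within the scatter). Compound 4 is estimated at 7000 nM, with an expected range of 2500 nM to 18000 nM.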

Compound 4, half-maximal inhibitory concentration: 3120 nM
Beside the measured number, compound 4's estimate is 2.2-fold (0.35 log units) above it; measured number inside the range.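

In this assay, for the compounds shown here, a ring on the oxygen on an aromatic ring gives the first step at this position with a readable size beyond the scatter, as 4-methylbenzyl replaces 4-methoxybutyl: a 2.6-fold lower number from compound 3 to compound 4 (0.42 log units; beyond the scatter). Compared with the two compounds held at the assay limit, the change also reads beyond the scatter, with an at least 3.2-fold lower number from compound 2 to compound 4 (0.50 log units; beyond the scatter) and an at least 3.2-fold lower number from compound 1 to compound 4 (0.50 log units; beyond the scatter). These two steps are floors and not sizes, set by a limit of the assay: the limit of > 10000 nM in this assay, at which 2 of the 4 values shown sit.

The compounds shown do not separate the effect of the aromatic ring from that of its methyl group, a question that plain benzyl or 4-chlorobenzyl on this oxygen would address. Going by these compounds, how the number responds to a longer chain ending in a ring, or to an amine on the same oxygen, also remains open.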